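Swapping a pyridine for cyclohexane on the amide nitrogen

This account rests on a few compounds, and the source may have more. Where it says the series, first, only, none or still open, it means among the compounds named here.

Compound 1 `Cc1ccc(OCC(=O)N(Cc2cccs2)c2cccnc2)cc1` and compound 2 `CCN(Cc1ccco1)C(=O)COc1ccc(C)cc1` were both tested in an assay on HEK293 cells for agonist activity at transient receptor potential cation channel subfamily M member 8 (Homo sapiens), read by fluorescence and calcium flux, with a stated time of 15 min; a higher number here means that more compound is needed for the effect, a lower number that less compound is needed. In this assay compound 1 gives 198 nM, the lower of the two numbers, while compound 2 gives 489 nM, a gap beyond the usual scatter. Compound 3 `Cc1ccc(OCC(=O)N(Cc2cccs2)C2CCCCC2)cc1` has not been measured; it differs from compound 1 by cyclohexyl in place of pyridin-3-yl on an amide-type nitrogen. Among the measured compounds shown here, no measured pair shows this particular change, so its effect is uncertain, and a step of modest size in either direction, or none beyond the scatter, seems plausible. The expected step of a 1.3-fold lower number from compound 1 to compound 3 (0.12 log units; within the scatter) is therefore small. Compound 3 is estimated at 150 nM, within a range from 40 nM to 600 nM.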

Compound 3, half-maximal effective concentration: 40000 nM
Beside the measured number, compound 3's estimate is 270-fold (2.43 log units) below it, outside the stated range (above it).
By their numbers in this assay, from the lowest: compound 1; then compound 2; then compound 3.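

At this position on the amide-type nitrogen, the choice of ring has a large effect: in this assay, cyclohexyl in place of pyridin-3-yl gives a 200-fold higher number from compound 1 to compound 3 (2.31 log units; beyond the scatter). Both groups are six-membered rings of 6 heavy atoms, so matching ring size and atom count does not preserve the activity. No available evidence explains the size of this step.

The change removes both the aromatic character and the ring nitrogen, and these two differences cannot be separated here. Phenyl, which is aromatic but has only carbon in its ring, would be the group to tell them apart.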